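Swapping phenyl for thiazolyl on a pyrrolidinone ring

The compounds below may be only part of what the source reports. "The series", "measured", "known", "first", "only" and "open" are said of these compounds alone.

Measured compounds:
- compound 1 `O=C1CC(c2ccccc2)CN1c1cnn2c1CN(C(=O)Nc1cc(F)c(F)c(F)c1)C(C1CC1)C2` — 12800 nM
- compound 2 `CC1(C)CN(C(=O)Nc2cc(F)c(F)c(F)c2)Cc2c(N3CC(C#N)CC3=O)cnn21` — > 200000 nM

Of the compounds shown here, two have been measured in a toxicity assay on HepG2 2.2.15 cells (Homo sapiens) for cytotoxicity, read by CellTiter-Glo; a higher number here means that more compound is tolerated, a lower number that less compound is tolerated. In this assay, among the compounds with values here, compound 1 gives 12800 nM, the only actual number among the two results. For compound 2 the result is a limit of the assay, > 200000 nM, not a number; this is the limit of > 200000 nM in this assay, at which 1 of the 2 values shown sits. Within the data shown here, no pair of measured compounds differs in just one place, so no measured step is available to calibrate against, and the two structures differ in several places at once.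

Compound 3 `O=C1CC(c2nccs2)CN1c1cnn2c1CN(C(=O)Nc1cc(F)c(F)c(F)c1)C(C1CC1)C2` is the unmeasured compound. It differs from compound 1 by 1,3-thiazol-2-yl in place of phenyl on a saturated ring carbon. Among the measured compounds shown here, with no measured step of this kind, the size of the change in this assay has to be guessed. A step from compound 1 to compound 3 of the size a 1.6-fold higher number from compound 1 to compound 3 (0.19 log units; within the scatter) is expected, that is, little or no change beyond the usual scatter, perhaps a slight rise in the tolerated concentration. Compound 3 is therefore expected to give about 20000 nM, within a range from 8000 nM to 60000 nM.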

Compound 3, half-maximal cytotoxic concentration: 115000 nM
The estimate for compound 3 lay 5.8-fold (0.76 log units) below the measured number, and the stated range ends below it.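

The step gives the first measured view of this position in this assay: 1,3-thiazol-2-yl in place of phenyl brings a 9.0-fold higher number from compound 1 to compound 3 (0.95 log units; beyond the scatter), so the tolerated concentration responds clearly to the group on this saturated ring carbon of the pyrrolidinone. The rest of compound 1 stays the same in this change, which ties the whole step to the exchange of a six-membered aromatic ring of carbon only for a five-membered aromatic ring with 2 hetero atoms. Nothing measured here shows which difference between the two rings accounts for the step, whether the ring size, the nitrogen or the sulfur.

A single pair leaves open whether the step comes from the thiazole itself or would also appear with other rings or groups at this position, such as pyridin-2-yl, a thiophene, or an open chain carrying an amine. Within the data shown here, it is also open whether the same exchange would give a step of similar size on a different core, such as the one in compound 2, which differs from the other compounds in several places at once.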